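The compounds below may be only part of what the source reports. "The series", "measured", "known", "first", "only" and "open" are said of these compounds alone.

A small series sharing one core was tested in an ADME assay on HFF cells (Homo sapiens) for cytotoxicity, read by MTT assay, with a stated time of 72 h; on this read-out higher numbers stand for weaker inhibition and lower numbers for stronger inhibition. Compound 1 `O=C1O[C@H]([C@@H](O)Cn2cc(-c3cccc(O)c3)nn2)C(OCc2ccccc2)=C1OCc1ccccc1`, which carries a 3-hydroxyphenyl group, gives 39000 nM. Compound 2 `O=C1O[C@H]([C@@H](O)Cn2cc(C3CC3)nn2)C(OCc2ccccc2)=C1OCc1ccccc1`, with cyclopropyl in that place, gives 24300 nM, and the measured step is a 1.6-fold lower number from compound 1 to compound 2 (0.21 log units; within the scatter). Compound 3 `O=C1O[C@H]([C@@H](O)Cn2cc(-c3cc(F)cc(F)c3)nn2)C(OCc2ccccc2)=C1OCc1ccccc1`, the 3,5-difluorophenyl member, gives > 100000 nM, which is a limit of the assay and not a number.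

Compound 4 `C[Si](C)(C)c1cn(C[C@H](O)[C@H]2OC(=O)C(OCc3ccccc3)=C2OCc2ccccc2)nn1` has not yet been measured. Its change from compound 3 is a group of 4 heavy atoms (3 carbon, 1 silicon; no ring) in place of a group of 8 heavy atoms (6 carbon, 2 fluorine; one six-membered aromatic ring of carbon only), on an aromatic carbon, on an aromatic carbon of a five-membered aromatic ring with 3 nitrogen. For the measured compounds named here, two measured steps bear on this change, both ending at the 3,5-difluorophenyl group: an at least 2.5-fold higher number from compound 1 to compound 3 (0.40 log units; beyond the scatter) and an at least 4.1-fold higher number from compound 2 to compound 3 (0.61 log units; beyond the scatter). Read in reverse, they suggest that removing this group should lower the number in this assay by at least a modest step, although no measured compound carries the entering group. Compound 2, which also lacks an aromatic ring in that place and gives 24300 nM, is the nearest guide. The expected change is an at least 2.5-fold lower number from compound 3 to compound 4 (0.39 log units; beyond the scatter). For compound 4 the estimated value is 40000 nM, with an expected range from 15000 nM to 100000 nM.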

Compound 4, half-maximal inhibitory concentration: 20000 nM
Estimate against measurement, compound 4: 2.0-fold (0.30 log units) above, and the stated range covers the measured number.
By their numbers in this assay, from the lowest: compounds 4, 2 and 1 (each within the scatter of the next). At a limit, above all of these: compound 3.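

In this assay, the ring-free group of carbon and silicon on the aromatic carbon of the five-membered ring gives an at least 5.0-fold lower number from compound 3 to compound 4 (0.69 log units; beyond the scatter), so a second group without an aromatic ring, after the cyclopropyl of compound 2, stands clearly apart from the 3,5-difluorophenyl member. The size of that step is only a bound, because compound 3 stands at a limit and not at a number: the limit of > 100000 nM in this assay, at which 1 of the 4 values shown sits. Against the other two neighbours the new group brings no separation, with a 1.2-fold lower number from compound 2 to compound 4 (0.08 log units; within the scatter) and a 2.0-fold lower number from compound 1 to compound 4 (0.29 log units; within the scatter), so three quite different groups at this position, one ringless, one a small carbon ring and one a 3-hydroxyphenyl, read alike, and only the 3,5-difluorophenyl group of compound 3 goes against that.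

The compounds shown leave open whether the separation of compound 3 comes with its two fluorine atoms or with the aromatic ring itself, a question that an unsubstituted phenyl group at the same place would address. They also leave open how an amine or a carboxylic acid on this carbon would read in this assay, and how far compound 3 truly lies from the others.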